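Taking the chloro group off compound 3

The source may hold more compounds than are shown below. What is called first, only, known or untested is meant among the compounds shown, and "the series" means these compounds.

In a functional assay on HeLa cells (Homo sapiens) for cytotoxicity, read by MTT assay, with a stated time of 48 h (a higher number here means a weaker inhibitor, a lower number a stronger inhibitor), compound 3 `CCOC(=O)[C@@]1(C(=O)Nc2ccccc2Cl)C[C@H]1c1cc(OC)c(OC)c(OC)c1` gives 14400 nM. Compound 2 `CCOC(=O)[C@@]1(C(=O)NCc2ccc(C)cc2)C[C@H]1c1cc(OC)c(OC)c(OC)c1` gives 19700 nM, and the two values lie within the scatter of each other. Compound 1 `CCOC(=O)[C@@]1(C(=O)Nc2ccccc2)C[C@@H]1c1cc(OC)c(OC)c(OC)c1` gives > 100000 nM, which is a limit and not a number. Compound 4 `CCOC(=O)[C@@]1(C(=O)Nc2ccccc2)C[C@H]1c1cc(OC)c(OC)c(OC)c1` carries hydrogen in place of chloro on an aromatic carbon, ortho to a large group: hydrogen in place of chloro on an aromatic carbon. Going by the values given here, the only measured step that bears on this change is a 1.4-fold lower number from compound 2 to compound 3 (0.14 log units; within the scatter), and no measured step isolates the chloro group. With that step so small, no change beyond the scatter is expected, only a slight lean towards a higher number: the estimated step is a 1.5-fold higher number from compound 3 to compound 4 (0.18 log units; within the scatter). Compound 4 is expected at 22000 nM, with an estimated range of 9000 nM to 70000 nM.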

Compound 4, half-maximal inhibitory concentration: > 100000 nM
Compound 4 gave a limit, no number; the forecaster's own chance of this, stated with the estimate: 20%; at least 4.5-fold (0.65 log units) between middle value and limit.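

In this assay, the chloro group on this aromatic carbon, ortho to a large group, now has a reading of its own: hydrogen in its place gives an at least 6.9-fold higher number from compound 3 to compound 4 (0.84 log units; beyond the scatter). Phenyl in place of 4-methylbenzyl on the amide-type nitrogen gives an at least 5.0-fold higher number from compound 2 to compound 4 (0.70 log units; beyond the scatter), so compound 2 and compound 3 both stand apart from compound 4. The step between compound 1 and compound 4 cannot be read, and the reading of drawn configuration stays closed: the limit of > 100000 nM in this assay, at which 2 of the 4 values shown sit.

As far as these compounds go, how far compound 4 lies past its limit remains open. So does whether bromo, methoxy or an amine at this place would match chloro.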